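This account rests on a few compounds, and the source may have more. Where it says the series, first, only, none or still open, it means among the compounds named here.

Measured so far in a physicochemical assay for acid dissociation, using potentiometric titration:
- compound 1 `CCC/N=C1\S/C(=C\c2ccc(O)c(C(F)(F)F)c2)C(=O)N1c1ccccc1C`: 6.6
- compound 2 `CCC/N=C1\S/C(=C\c2ccc(O)c(C(C)C)c2)C(=O)N1c1ccccc1C`: 8.6

Of these two compounds, compound 2 stands higher, with 8.6, so it gives up its proton less readily. Still unmeasured is compound 3 `CCC/N=C1\S/C(=C\c2ccc(O)c(Br)c2)C(=O)N1c1ccccc1C`, which keeps the shared core of compound 2 and changes a single group: bromo in place of isopropyl on an aromatic carbon, ortho to a hydroxy group (bromo in place of isopropyl on an aromatic carbon).

Among the compounds with values here, only one measured step bears on this change. It involves the same aromatic carbon, where isopropyl replaces trifluoromethyl, and it is large: a number 2.00 log units higher from compound 1 to compound 2 (beyond the scatter). Within the data shown here, that step shows that exchanging the group on this carbon can shift this assay considerably, but no compound measured so far carries bromo. The two values therefore offer only a rough span, and a result between them seems the most reasonable expectation. A sizeable drop is expected, smaller than the measured step. The expected step is a number 1.40 log units lower from compound 2 to compound 3 (beyond the scatter). For compound 3 the estimated value is 7.2, with an expected range from 6.6 to 7.8.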

Compound 3, acid dissociation constant: 6.4
Beside the measured number, compound 3's estimate is 0.80 log units above it; the measured number lies below the stated range.
By their numbers in this assay, from the lowest: compounds 3 and 1 (each within the scatter of the next); then compound 2.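

In this assay, bromo in place of isopropyl on this aromatic carbon, ortho to a hydroxy group, brings a number 2.20 log units lower from compound 2 to compound 3 (beyond the scatter) and shows that a large shift at this position does not depend on trifluoromethyl being the group present. Bromo in place of trifluoromethyl gives a number 0.20 log units lower from compound 1 to compound 3 (within the scatter) and so places these two groups on a level that this measurement cannot separate, while compound 2, with isopropyl, stands apart from both by a clear margin. The numbers show how the three groups rank at this carbon, but no measurement is available that would explain why bromo and trifluoromethyl match so closely or why isopropyl differs.

Within the data shown here, with only three groups seen at this carbon, it remains open where others, such as a nitrile, a methoxy group or an amine, would fall, and whether any would land in the wide gap separating isopropyl from the other two. On these data alone, it is also open whether the same exchanges would produce steps of similar size on a different aromatic carbon or with a different shared core.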